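The source may hold more compounds than are shown below. What is called first, only, known or untested is meant among the compounds shown, and "the series" means these compounds.

Series notes. In an assay on isolated protein for binding affinity to Orexin/Hypocretin receptor type 1 (Homo sapiens), read by radioligand binding (on this read-out lower numbers stand for stronger inhibition and higher numbers for weaker inhibition), compound 1, `Cc1cnc(OC[C@@]2(c3ccccc3)C[C@H]2C(=O)Nc2ccc(C#N)cn2)c(C)n1`, gives 73 nM. Compound 2, `CCn1cc(OCC2(c3ccccc3)CC2C(=O)Nc2ccc(C#N)cn2)c(C)n1`, gives 391 nM, the highest of the two numbers shown; its nearest neighbour is compound 1, whose lower number lies beyond the scatter. Compound 3, `CCn1cc(OC[C@@]2(c3ccccc3)C[C@H]2C(=O)Nc2ccc(C#N)cn2)c(C)n1`, differs from compound 2 as follows: the two compounds have the same atoms and bonds; at least one stereo element is drawn with a configuration in one of them and without one in the other: 2 of 2 stereo elements differ; a stereocentre at a saturated ring carbon is drawn without a configuration in compound 2 and S in compound 3; a stereocentre at a saturated ring carbon is drawn without a configuration in compound 2 and R in compound 3. Compound 3 thus carries the same configuration as compound 1. For the measured compounds named here, with only two compounds measured, a moderate downward step from compound 2 to compound 3 is expected, of a 2.0-fold lower number from compound 2 to compound 3 (0.29 log units; within the scatter). Compound 3 is estimated at 200 nM, with a range from 80 nM to 450 nM.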

Compound 3, inhibition constant in the Orexin/Hypocretin receptor type 1 assay: 171 nM
Compound 3: middle estimate off by 1.2-fold (0.07 log units), on the high side, within the range that was stated.
By their numbers in the Orexin/Hypocretin receptor type 1 assay, from the lowest: compound 1; then compound 3; then compound 2.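

For the compounds shown here, in the Orexin/Hypocretin receptor type 1 assay, compound 2 gives 391 nM and compound 3 gives 171 nM; the stereo change alone gives a 2.3-fold lower number from compound 2 to compound 3 (0.36 log units; beyond the scatter), the first step that can be tied to configuration: the fact that one of compounds 2 and 3 is drawn with a defined configuration and the other without, at the place where they differ. With the configuration matched, 1-ethyl-3-methyl-1H-pyrazol-4-yl in place of 3,5-dimethylpyrazin-2-yl gives a 2.3-fold higher number from compound 1 to compound 3 (0.37 log units; beyond the scatter), so the group exchange carries a step of its own. In a physicochemical assay for solubility, in phosphate buffer, at pH 7.4 (a higher number here means a more soluble compound, a lower number a less soluble compound), compound 2 gives 78000 nM and compound 3 gives 64000 nM; the same stereo change gives a 1.2-fold lower number from compound 2 to compound 3 (0.09 log units; within the scatter), which lies within the scatter.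

As far as these compounds go, the mirror-image configuration of compound 3 remains open. So does the effect in the Orexin/Hypocretin receptor type 1 assay of a longer chain in place of the ethyl, or of a carboxylic acid in place of the nitrile.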